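Bromophenyl to Difluorophenyl: a Step into the Unknown

This account rests on a few compounds, and the source may have more. Where it says the series, first, only, none or still open, it means among the compounds named here.

Compound 1, `COc1cc(-c2nnc(SCC(=O)c3ccccc3)n2N)cc(OC)c1OC`: in a functional assay on HeLa cells (Homo sapiens) for antiproliferative activity, read by MTT assay, with a stated time of 48 h (a lower number here means a stronger inhibitor, a higher number a weaker inhibitor), compound 1 reached only the assay limit, > 100000 nM.
Compound 2, `COc1cc(-c2nnc(SCC(=O)c3cccc(Br)c3)n2N)cc(OC)c1OC`: in this assay compound 2 gives 77500 nM.

Going by the values given here, compound 2 holds the only proper number among the two values; the other is a limit of the assay, (the limit of > 100000 nM in this assay, at which 1 of the 2 values shown sits). Putting bromo in place of hydrogen on an aromatic carbon gave an at least 1.2-fold lower number from compound 1 to compound 2 (0.11 log units; that floor lies within the scatter), a floor that lies within the scatter, so nothing beyond the scatter has been seen so far. Compound 3, `COc1cc(-c2nnc(SCC(=O)c3ccc(F)c(F)c3)n2N)cc(OC)c1OC`, differs from compound 2 by 3,4-difluorophenyl in place of 3-bromophenyl on a carbonyl carbon. Among the compounds with values here, the only measured step that touches the same ring is the one from compound 1 to compound 2, and it stayed within the scatter; no measured step exchanges one halogen pattern for another. On that basis the step from compound 2 to compound 3 in this assay is expected to be a 1.0-fold higher number from compound 2 to compound 3 (0.01 log units; within the scatter), no larger than the scatter and in no settled direction. Compound 3 is therefore estimated at 80000 nM, within 30000 nM to 250000 nM, with a real chance that only a limit is reported.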

Compound 3, half-maximal inhibitory concentration: > 100000 nM
Compound 3: no number, only a limit (the forecaster's own chance of this, stated with the estimate: 40%); at least 1.2-fold (0.09 log units) between middle value and limit.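

Setting 3,4-difluorophenyl in place of 3-bromophenyl on the carbonyl carbon gave an at least 1.2-fold higher number from compound 2 to compound 3 (0.11 log units; that floor lies within the scatter) in this assay. This position has now taken an exchange of one halogen pattern for another, and that exchange, like the earlier bromo step, has shown nothing beyond the scatter. Compound 3 joins compound 1 at a limit of the assay, so the step between those two cannot be read, and the values now gather at that limit: the limit of > 100000 nM in this assay, at which 2 of the 3 values shown sit.

From the compounds shown here alone, only compound 2 holds a proper number, so how far the true values of compound 1 and compound 3 lie from it stays open. Also open, going by these compounds, is what an amine, a carboxylic acid or a nitrile on this phenyl ring would give in this assay, and whether any such group would produce a step clearly beyond the scatter.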